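The source may hold more compounds than are shown below. What is called first, only, known or untested is meant among the compounds shown, and "the series" means these compounds.

Of the compounds shown here, three share one core and have been tested in a functional assay for antagonist activity at transient receptor potential cation channel subfamily V member 1 (Homo sapiens), read by FLIPR and calcium flux; on this read-out lower numbers stand for stronger inhibition and higher numbers for weaker inhibition. Compound 1 `Cc1ccccc1N1CCC(C(=O)Nc2ccc3c(c2)NC(=O)CO3)CC1` gives 150 nM, compound 2 `CC(C)c1ccccc1N1CCC(C(=O)Nc2ccc3c(c2)NC(=O)CO3)CC1` gives 180 nM, and compound 3 `O=C1COc2ccc(NC(=O)C3CCN(c4cccc(Cl)c4)CC3)cc2N1` gives 190 nM, the highest of the three numbers as they stand, although a 1.3-fold higher number from compound 1 to compound 3 (0.10 log units; within the scatter) and a 1.1-fold higher number from compound 2 to compound 3 (0.02 log units; within the scatter) both remain within the scatter. Compound 4 `O=C1COc2ccc(NC(=O)C3CCN(c4ccccc4C(F)(F)F)CC3)cc2N1` has not yet been measured; it differs from compound 3 by 2-(trifluoromethyl)phenyl in place of 3-chlorophenyl on an amine nitrogen in a ring. The measured steps that bear on this are the two just named, in which 3-chlorophenyl replaced 2-methylphenyl or 2-isopropylphenyl with little effect, and a 1.2-fold higher number from compound 1 to compound 2 (0.08 log units; within the scatter) shows that isopropyl in place of methyl also changed little. A step of about a 1.1-fold lower number from compound 3 to compound 4 (0.05 log units; within the scatter) is therefore expected, with no direction beyond the scatter. Compound 4 is estimated at 170 nM, between 80 nM and 360 nM.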

Compound 4, half-maximal inhibitory concentration: 380 nM
Estimate against measurement, compound 4: 2.2-fold (0.35 log units) below, outside the stated range (above it).
By their numbers in this assay, from the lowest: compounds 1, 2, 3 and 4 (each within the scatter of the next, the first and the last beyond it).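

Among the compounds shown here, until now, every swap on the phenyl group at this amine nitrogen stayed within the scatter in this assay, but trifluoromethyl in place of methyl or isopropyl on the same aromatic carbon gives the first steps beyond it, both modest (a 2.5-fold higher number from compound 1 to compound 4 (0.40 log units; beyond the scatter) and a 2.1-fold higher number from compound 2 to compound 4 (0.32 log units; beyond the scatter)). The step from the 3-chlorophenyl group remains within the scatter (a 2.0-fold higher number from compound 3 to compound 4 (0.30 log units; within the scatter)), so this position tolerates all four groups with only small differences. Nothing measured here gives a reason for these steps. Still open, from the compounds shown here alone, is whether a methoxy group or an amine on this phenyl ring would shift the number further, and in which direction.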